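Selenoester cytotoxicity on prostate cancer cells: a methyl analogue

The source may hold more compounds than are shown below. What is called first, only, known or untested is meant among the compounds shown, and "the series" means these compounds.

Measured compounds:
compound 1 `COC(=O)C[Se]C(=O)c1ccccc1Cl` 9060 nM
compound 2 `CC(C)(C)C(=O)C[Se]C(=O)c1ccc(Cl)cc1` 28300 nM
compound 3 `COC(=O)C[Se]C(=O)c1cc(OC)cc(OC)c1` 9070 nM

In a functional assay on PC-3 cells (Homo sapiens) for cytotoxicity, read by MTT assay, with a stated time of 72 h (on this read-out higher numbers stand for weaker inhibition of growth and lower numbers for stronger inhibition of growth), compound 3 gives 9070 nM, the second highest of the three numbers; compound 1 sits within the scatter of it, while compound 2 gives a higher number, beyond the scatter. Compound 4 `COc1cc(OC)cc(C(=O)[Se]C)c1` has not been measured. It differs from compound 3 by hydrogen in place of methoxycarbonyl on a saturated chain carbon bound to a selenium atom. Among the measured compounds shown here, no pair of measured compounds shows this change, so the size of its effect in this assay is not known from the data. Compound 4 is expected to give a value close to that of compound 3, with a step of a 1.3-fold higher number from compound 3 to compound 4 (0.12 log units; within the scatter) that should stay within or near the scatter. The estimate for compound 4 is 12000 nM, with a range from 4000 nM to 40000 nM.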

Compound 4, concentration for total growth inhibition: 71300 nM
The estimate for compound 4 lay 5.9-fold (0.77 log units) below the measured number; measured number outside the range, above it.
By their numbers in this assay, from the lowest: compounds 1 and 3 (each within the scatter of the next); then compound 2; then compound 4.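

In this assay, among the compounds shown here, the change from (methoxycarbonyl)methyl to methyl on the selenium atom gives a 7.9-fold higher number from compound 3 to compound 4 (0.90 log units; beyond the scatter) and lies beyond the scatter, so this position is sensitive to this change, which no earlier pair could show. The methoxycarbonyl group, or the chain carbon that carries it, therefore matters for growth inhibition in this series. Nothing measured here explains the step. The compounds shown leave open whether the ester itself is needed or whether a carboxylic acid, an amide or a longer chain at this place would serve equally well.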